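The source may report more compounds than this note shows. Statements on the series, on what has been measured and on what is new or still open speak of the compounds shown alone.

In a functional assay on NFS-60 cells (Mus musculus) for inhibition, with a stated time of 72 h (a higher number here means a weaker inhibitor of growth, a lower number a stronger inhibitor of growth), the measured compounds are:
- compound 1 `Nc1ncnc2c(C(=O)Nc3cccc4c3c(Br)nn4Cc3ccccc3)csc12` gives 1010 nM 
- compound 2 `COc1ccc(Cn2nc(Br)c3c(NC(=O)c4csc5c(N)ncnc45)cccc32)cc1` gives 2390 nM 
- compound 3 `Nc1ncnc2c(C(=O)Nc3cccc4c3c(Br)nn4CC3CCCCC3)csc12` gives 254 nM 

Compound 3 has the lowest number of the three. The next step leads to compound 4 `C#CCn1nc(Br)c2c(NC(=O)c3csc4c(N)ncnc34)cccc21`, with ethynyl in place of cyclohexyl on a saturated chain carbon bound to an aromatic nitrogen. Two modest measured steps alter this same substituent and end at compound 3 (a 4.0-fold lower number from compound 1 to compound 3 (0.60 log units; beyond the scatter); a 9.4-fold lower number from compound 2 to compound 3 (0.97 log units; beyond the scatter)). Among the measured compounds shown here, no measured compound carries ethynyl, so these steps guide the estimate only loosely. A modest move to a higher number is expected, an estimated 2.8-fold higher number from compound 3 to compound 4 (0.44 log units; beyond the scatter) in this assay. For compound 4 the estimate is 700 nM (expected range 230 nM to 2100 nM).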

Compound 4, concentration for 50% growth inhibition: > 10000 nM
Compound 4: no number, only a limit (the forecaster's own chance of this, stated with the estimate: 5%); middle value at least 14-fold (1.15 log units) away from the limit.
By their numbers in this assay, from the lowest: compound 3; then compound 1; then compound 2. At a limit, above all of these: compound 4.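

In this assay compound 4 gives only a limit of the assay, not a number: the limit of > 10000 nM in this assay, at which 1 of the 4 values shown sits. Ethynyl at this place, on a saturated chain carbon bound to an aromatic nitrogen, gives an at least 39-fold higher number from compound 3 to compound 4 (1.59 log units; beyond the scatter), an at least 9.9-fold higher number from compound 1 to compound 4 (0.99 log units; beyond the scatter) and an at least 4.1-fold higher number from compound 2 to compound 4 (0.62 log units; beyond the scatter). The earlier compounds shown here compared only ring-bearing groups here, whereas these steps show that this ring-free group sits above all three, so the position does not accept every substituent.

As far as these compounds go, whether the missing ring or the triple bond matters remains open. A butyl chain at this place would separate the two.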